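Pyrazolyl-amide series: aryl swap on the tetrazole

The source may report more compounds than this note shows. Statements on the series, on what has been measured and on what is new or still open speak of the compounds shown alone.

Measured so far:
- compound 1, `Cc1cc(NC(=O)Cn2nnc(-c3ccccc3)n2)n(C2CCC(F)(F)CC2)n1`: 68%
- compound 2, `O=C(Cn1nnc(-c2ccccc2)n1)Nc1cc(C2(C(F)(F)F)CC2)nn1C1CCCCC1`: "not active" (no number reported)
- compound 3, `Cc1cc(NC(=O)Cn2nnc(-c3cccc(Cl)c3)n2)n(C2CCCCC2)n1`: 89%

In an assay on HEK293 cells for activation of Kir3.1/Kir3.2 (Homo sapiens), read by thallium flux (on this read-out higher numbers stand for larger maximal responses and lower numbers for smaller maximal responses), compound 3 gives 89%, the highest of the two numbers in hand. The nearest number belongs to compound 1, which gives 68%, a gap that lies beyond the usual scatter. Compound 2 returned "not active" (no number reported) without a number, so no comparison to it is possible. Among the compounds with values here, compound 1 and compound 3 differ at more than one place, and no single step between them is available.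

The next compound, compound 4, `Cc1cc(NC(=O)Cn2nnc(-c3ccc(F)c(F)c3)n2)n(C2CCCCC2)n1`, keeps the core and the ring on the nitrogen of compound 3 and changes only the aryl group on the tetrazole: 3,4-difluorophenyl in place of 3-chlorophenyl on an aromatic carbon.

Within the data shown here, no step of this kind has been measured, so its size is unknown. The expectation is that the step of a number 9 percentage points lower from compound 3 to compound 4 (within the scatter) stays within the scatter, with a slight tilt downward. Compound 4 is accordingly expected at 80%, with a range from 60% to 100%.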

Compound 4, largest response reached (Emax), in percent of the reference or control that the assay uses: 93%
The estimate for compound 4 lay 13 percentage points below the measured number; the range from low to high includes it.
By their numbers in this assay, from the lowest: compound 1; then compounds 3 and 4 (each within the scatter of the next).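

In this assay the series now has its first step at a single place, the aryl group on the tetrazole, where 3,4-difluorophenyl in place of 3-chlorophenyl gives a number 4 percentage points higher from compound 3 to compound 4 (within the scatter). This position therefore accepts two fluorine atoms in place of one chlorine atom with no separable change in the maximal response, a reading that holds for this pair alone. Nothing in hand bears on why the two aryl groups read alike.

Open, going by these compounds, is whether this position stays as tolerant with a carboxylic acid, a dimethylamino group or a methoxy group on the phenyl ring. Also open, on these data alone, is whether the phenyl ring itself can give way to a pyridine ring or a butyl chain while the maximal response holds.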